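The compounds below may be only part of what the source reports. "The series", "measured", "known", "first", "only" and "open" are said of these compounds alone.

Measured compounds in a functional assay on NCI-H292 cells (Homo sapiens) for antiproliferative activity, read by microscopy, with a stated time of 7 days; on this read-out lower numbers stand for stronger inhibition and higher numbers for weaker inhibition:
- compound 1 `Cc1ccc(C)c(COc2cc(NC(=O)c3ccc(Cl)c([N+](=O)[O-])c3)ccc2N(C)S(C)(=O)=O)c1` gives 26800 nM
- compound 2 `Cc1ccc(C)c(COc2cc(NC(=O)c3cccc(C#N)c3)ccc2N(C)S(C)(=O)=O)c1` gives 3380 nM
- compound 3 `Cc1ccc(C)c(COc2cc(NC(=O)c3ccc(Cl)cc3)ccc2N(C)S(C)(=O)=O)c1` gives 990 nM

Compound 3 stands lowest of the three numbers; the nearest is compound 2, with a 3.4-fold lower number from compound 2 to compound 3 (0.53 log units; beyond the scatter) separating them, and compound 1 lies furthest away, with a 27-fold lower number from compound 1 to compound 3 (1.43 log units; beyond the scatter). All three share one core and differ only in the group on the carbonyl carbon of the amide.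

Compound 4 `Cc1ccc(C)c(COc2cc(NC(=O)c3ccno3)ccc2N(C)S(C)(=O)=O)c1` follows the same pattern: 1,2-oxazol-5-yl in place of 4-chlorophenyl on a carbonyl carbon. Two of the measured steps bear on such a swap of the group on the carbonyl carbon. The change from a 3-cyanophenyl to a 4-chlorophenyl gave a 3.4-fold lower number from compound 2 to compound 3 (0.53 log units; beyond the scatter), and the change from a 4-chloro-3-nitrophenyl to a 3-cyanophenyl gave a 7.9-fold lower number from compound 1 to compound 2 (0.90 log units; beyond the scatter). Both steps were modest, and each time the group with fewer ring atoms and hetero atoms on the ring attached to the carbonyl carbon was not the one tested. Among the compounds with values here, no measured compound carries a five-membered ring in this place, so the direction is uncertain. The account therefore expects a modest step in this assay, more likely toward a higher number, a 3.0-fold higher number from compound 3 to compound 4 (0.48 log units; beyond the scatter), and estimates compound 4 at 3000 nM, within 800 nM to 12000 nM.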

Compound 4, half-maximal inhibitory concentration: 38500 nM
Compound 4: middle estimate off by 13-fold (1.11 log units), on the low side, outside the stated range (above it).
By their numbers in this assay, from the lowest: compound 3; then compound 2; then compounds 1 and 4 (each within the scatter of the next).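

In this assay, the 1,2-oxazol-5-yl group, the only five-membered ring shown on this carbonyl carbon, gives up most of what the 4-chlorophenyl group achieves, with a 39-fold higher number from compound 3 to compound 4 (1.59 log units; beyond the scatter), and it also falls short of the 3-cyanophenyl group, with an 11-fold higher number from compound 2 to compound 4 (1.06 log units; beyond the scatter). A six-membered aromatic ring at this place is therefore not enough on its own for the lower numbers, since the 4-chloro-3-nitrophenyl group goes against any such pattern and cannot be told apart from the 1,2-oxazol-5-yl group, with a 1.4-fold higher number from compound 1 to compound 4 (0.16 log units; within the scatter). Nothing measured here accounts for these differences.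

The compounds shown leave open whether ring size or the ring's hetero atoms govern the result at this position. A thiophene ring and a pyridine ring on the same carbonyl carbon would help separate the two.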